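Cytotoxicity notes on a chain-shortened series

The source may report more compounds than this note shows. Statements on the series, on what has been measured and on what is new or still open speak of the compounds shown alone.

Compound 1 `CCCCCCCCc1cc2cn(COCCO)c(O)nc-2n1` gives 65000 nM in a functional assay on HEL cells (Homo sapiens); on this read-out lower numbers stand for higher toxicity in this test and higher numbers for lower toxicity in this test. Compound 2 `CCCCCCCCC#Cc1cc2cn(COCCO)c(=O)nc2o1` gives 42000 nM in this assay; the difference between the two cores is not broken down here. Compound 3 `CCCCC#Cc1cc2cn(COCCO)c(=O)nc2o1` reaches only a limit of this assay, > 50000 nM. The change hydrogen in place of butyl on a saturated chain carbon, four bonds along the chain from a triple-bonded carbon made the step of an at least 1.1-fold higher number from compound 2 to compound 3 (0.07 log units; that floor lies within the scatter), which is a floor only because of the limit of > 50000 nM in this assay, at which 1 of the 3 values shown sits. Compound 4 `CCCCc1cc2cn(COCCO)c(O)nc-2n1`, not yet measured, carries the same kind of change from compound 1, (hydrogen in place of butyl on a saturated chain carbon, four bonds along the chain from an aromatic carbon), though here the place is four bonds along the chain from an aromatic carbon rather than from a triple-bonded carbon. Compound 4 is expected to give 85000 nM in this assay, between 40000 nM and 200000 nM. This rests on compound 1 at 65000 nM and on the earlier step, so the expected step is a 1.3-fold higher number from compound 1 to compound 4 (0.12 log units; within the scatter).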

Compound 4, half-maximal cytotoxic concentration: > 200000 nM
Compound 4 gave a limit, no number (the forecaster's own chance of this, stated with the estimate: 35%); at least 2.3-fold (0.37 log units) between middle value and limit.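

Compound 4 reaches only a limit in this assay, > 200000 nM, which is not a number. On the core of compound 1, hydrogen in place of butyl, on a saturated chain carbon four bonds along the chain from an aromatic carbon, gives an at least 3.0-fold higher number from compound 1 to compound 4 (0.48 log units; beyond the scatter). That step is beyond the scatter, but the earlier floor is not, so neither a shared size nor a difference between the two cores is established: the same change on two cores in this assay, an at least 1.1-fold higher number (0.07 log units; that floor lies within the scatter) from compound 2 to compound 3 and an at least 3.0-fold higher number (0.48 log units; beyond the scatter) from compound 1 to compound 4; the limit leaves it open whether they differ

From the compounds shown here alone, the true values of compound 3 and compound 4 remain unknown beyond their limits, so the two steps stay floors. Also open, going by these compounds, is how an amine or a carboxylic acid in place of butyl would read in this assay on either core.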